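Thiophene enone series: benzylthio aryl change, growth inhibition

The source may report more compounds than this note shows. Statements on the series, on what has been measured and on what is new or still open speak of the compounds shown alone.

Measured compounds:
compound 1 `Cc1ccsc1/C=C(/SCc1ccc(F)cc1)C(=O)c1ccc(Br)cc1`, 50000 nM
compound 2 `Cc1ccsc1/C=C(/SCc1ccc(Cl)cc1)C(=O)c1ccc(Cl)cc1`, 50000 nM
compound 3 `Cc1ccsc1/C=C(/SCc1ccc(F)cc1)C(=O)c1ccc(Cl)cc1`, 50000 nM

In a functional assay on DU-145 cells (Homo sapiens) for inhibition, read by trypan blue exclusion, with a stated time of 96 h (on this read-out lower numbers stand for stronger inhibition of growth and higher numbers for weaker inhibition of growth), compound 3 stands level with compounds 1 and 2; no order among the three can be read. The step to compound 4 `Cc1ccsc1/C=C(/SCc1ccc(Cl)c(Cl)c1)C(=O)c1ccc(Cl)cc1` is 3,4-dichlorophenyl in place of 4-fluorophenyl on a saturated chain carbon bound to a sulfur. For the measured compounds named here, two measured steps bear on halogen changes here: no change at the digits printed from compound 1 to compound 3 (within the scatter) and no change at the digits printed from compound 2 to compound 3 (within the scatter), both within the scatter. Nothing in the series shows any halogen exchange moving this assay, so for compound 4 no change beyond the scatter is expected, no change at the digits printed from compound 3 to compound 4 (within the scatter). Compound 4 is estimated at 50000 nM, with a range from 20000 nM to 50000 nM in this assay.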

Compound 4, concentration for 50% growth inhibition: 50000 nM
For compound 4 middle estimate and measured number coincide at the digits printed, and the stated range covers the measured number.
By their numbers in this assay, from the lowest: compounds 1, 2, 3 and 4 (each within the scatter of the next).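

Notes on the series: the earlier steps only exchanged one halogen for another, whereas here two chlorine atoms replace one fluorine on the benzyl ring, and this assay still shows no change at the digits printed from compound 3 to compound 4 (within the scatter). Adding a chloro in place of hydrogen on that ring likewise shows no change at the digits printed from compound 2 to compound 4 (within the scatter), so neither a second halogen nor the 3,4-dichlorobenzyl group separates these compounds. No evidence on the reason for this flat result is available. Still open, going by these compounds, is whether an amine or a carboxylic acid on this ring, or a longer chain in place of the benzyl, would move growth inhibition.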